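Swapping the Cyclohexyl Ring for a Smaller Amide-Bearing Ring

The compounds below may be only part of what the source reports. "The series", "measured", "known", "first", "only" and "open" are said of these compounds alone.

Compound 1 `CO[C@H]1CC[C@@H](Nc2cc(NCc3cnccc3C(F)(F)F)ncc2C#N)CC1` is the starting point of this step. Within the data shown here, in an assay on isolated protein for inhibition of protein kinase C theta type (Homo sapiens), read by TR-FRET, with a stated time of 2 h (on this read-out higher numbers stand for weaker inhibition and lower numbers for stronger inhibition), compound 1 gives 58 nM, the highest of the three numbers measured so far, although each of the other two lies within the usual scatter of it. Compound 2 `CN(C)C(=O)[C@H]1CC[C@@H](Nc2cc(NCc3cnccc3C(F)(F)F)ncc2C#N)CC1` gives 38 nM in this assay, and the step of a 1.5-fold lower number from compound 1 to compound 2 (0.18 log units; within the scatter) shows that exchanging the group on the saturated ring changed little here. Compound 3 `CC(C)(F)c1ncncc1CNc1cc(N[C@H]2CC[C@@H](O)CC2)c(C#N)cn1`, which carries a different aromatic piece and a hydroxyl on its saturated ring, gives 32 nM.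

Compound 4 `CC1(C)[C@H](Nc2cc(NCc3cnccc3C(F)(F)F)ncc2C#N)C[C@H]1C(N)=O` has not yet been measured. It differs from compound 1 by 3-carbamoyl-2,2-dimethylcyclobutyl in place of 4-methoxycyclohexyl on a nitrogen on an aromatic ring. Among the measured compounds shown here, the only measured step, from compound 1 to compound 2, also alters the group on the saturated ring and stayed within the scatter, but no measured pair exchanges a six-membered ring for a four-membered one, so that part of the change is untested. The expectation is therefore a step of a 1.2-fold higher number from compound 1 to compound 4 (0.08 log units; within the scatter), with wide uncertainty. Compound 4 is estimated to give 70 nM in this assay, expected to fall between 20 nM and 250 nM.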

Compound 4, half-maximal inhibitory concentration: 140 nM
The estimate for compound 4 lay 2.0-fold (0.30 log units) below the measured number; low and high end bracket the measured number.
By their numbers in this assay, from the lowest: compounds 3, 2 and 1 (each within the scatter of the next); then compound 4.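

Replacing 4-methoxycyclohexyl with 3-carbamoyl-2,2-dimethylcyclobutyl on a nitrogen on an aromatic ring gives a 2.4-fold higher number from compound 1 to compound 4 (0.38 log units; beyond the scatter) in this assay, and this is the only step among these compounds that lies beyond the scatter. The exchange from compound 1 to compound 2 kept the six-membered ring and altered only its substituent, whereas this change shows that a new ring at this position can move the number measurably, though modestly, while compound 4 still gives 140 nM and so keeps inhibition in the nanomolar range. The ring size, the two methyl groups and the carbamoyl group all change together in this one step, and no measurement offered here explains the shift or assigns it to any one of them.

Still open, as far as these compounds go, is whether a plain cyclobutyl ring without the two methyl groups, or a five-membered cyclopentyl ring, would bring the number back towards that of compound 1. From the compounds shown here alone, it is equally open whether a carboxylic acid, a primary amine or a dimethylcarbamoyl group in place of the carbamoyl group on the four-membered ring would raise or lower the number.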